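The source may report more compounds than this note shows. Statements on the series, on what has been measured and on what is new or still open speak of the compounds shown alone.

Working notes on the series.

Compound 1 `O=C(NN1CCOCC1)c1c(O)c2cccnc2n(-c2ccccc2)c1=O` is tested in a functional assay on the whole organism for inhibition, with Rattus norvegicus as the target, read by paw edema, at a dose of 100 mg/kg by the oral route (on this read-out higher numbers stand for more inhibition at the one dose given (going by the name of the read-out) and lower numbers for less inhibition), and gives -8.5%. Among the three numbers in hand, compound 1 stands lowest, though its steps to compound 3 and to compound 2 are within the scatter. Compound 2 `Cc1ccc(NC(=O)c2c(O)c3cccnc3n(-c3ccccc3)c2=O)cc1` gives -3.5% in this assay, and compound 3 `Nc1ccc(NC(=O)c2c(O)c3cccnc3n(-c3ccccc3)c2=O)cc1` gives -5.5%.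

Compound 4 `O=C(Nc1ccc(Cl)nc1)c1c(O)c2cccnc2n(-c2ccccc2)c1=O` is not yet measured. Its difference from compound 1 is 6-chloropyridin-3-yl in place of morpholin-4-yl on an amide-type nitrogen.

Two steps in hand change the same amide-type nitrogen of compound 1. The step of a number 5 percentage points higher from compound 1 to compound 2 (within the scatter) and the step of a number 3 percentage points higher from compound 1 to compound 3 (within the scatter) both stay within the scatter, and the further step a number 2 percentage points lower from compound 2 to compound 3 (within the scatter) also stays within the scatter. Going by the values given here, no step moves the read-out beyond its scatter, so a group exchange at the amide-type nitrogen of compound 1 is expected to leave this assay about where it is, with no step beyond the scatter in either direction.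

The expected step is a number 4.5 percentage points higher from compound 1 to compound 4 (within the scatter). Compound 4 is therefore estimated at -4%, with a range from -16% to 9%.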

Compound 4, a percentage reported as inhibition, in the whole organism at one dose (the size of the read-out at that dose, not a potency): 9.2%
Compound 4: middle estimate off by 13.2 percentage points, on the low side; the measured number lies above the stated range.
By their numbers in this assay, from the lowest: compounds 1, 3 and 2 (each within the scatter of the next); then compound 4.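

In this assay the step to 6-chloropyridin-3-yl on the amide-type nitrogen reads a number 17.7 percentage points higher from compound 1 to compound 4 (beyond the scatter) and a number 14.7 percentage points higher from compound 3 to compound 4 (beyond the scatter) and also a number 12.7 percentage points higher from compound 2 to compound 4 (beyond the scatter) against morpholin-4-yl, 4-aminophenyl and 4-methylphenyl. Going by these compounds alone, the earlier exchanges at this nitrogen all stayed within the scatter, so this is the first sign that the group at this place can shift the read-out, and compound 4 now stands apart from all three other compounds. Nothing in hand explains the step.

The compounds shown do not separate the part played by the chlorine from that of the ring nitrogen, a question that 4-chlorophenyl and pyridin-3-yl on the same nitrogen would address. On these data alone, how far the step extends with other chloropyridinyl arrangements or with a carboxylic acid on the aromatic ring also stays open.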